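Aryl Swap on the Ring Nitrogen: Expecting Compound 4

The compounds below may be only part of what the source reports. "The series", "measured", "known", "first", "only" and "open" are said of these compounds alone.

Compound 1 `Nc1scc(CN2CCN(c3cccc(Cl)c3Cl)CC2)c1C(=O)c1ccc(Cl)cc1`: 1%
Compound 2 `Nc1scc(CN2CCN(c3ccc(F)cc3Cl)CC2)c1C(=O)c1ccc(Cl)cc1`: 6.1%
Compound 3 `COc1ccc(N2CCN(Cc3csc(N)c3C(=O)c3ccc(Cl)cc3)CC2)cc1`: -1.2%

Of the compounds shown here, three sharing one core have been tested in a functional assay on CHO cells with adenosine receptor A1 (Homo sapiens) as the target, read by cAMP accumulation and immunoassay, with a stated time of 6 min, tested at 0.01 uM; a higher number here means a weaker effect of the compound at the concentration tested, a lower number a stronger effect. Each carries a different aromatic group on an amine nitrogen in a ring. Compound 3 stands close to the other two: the steps of a number 2.2 percentage points lower from compound 1 to compound 3 (within the scatter) and a number 7.3 percentage points lower from compound 2 to compound 3 (within the scatter) both lie within the scatter, as does a number 5.1 percentage points higher from compound 1 to compound 2 (within the scatter). Compound 4 `Nc1scc(CN2CCN(c3ccc(F)cc3F)CC2)c1C(=O)c1ccc(Cl)cc1` alters this same position: 2,4-difluorophenyl in place of 4-methoxyphenyl on an amine nitrogen in a ring. The two earlier swaps at that position bear directly on this one, and neither moved the read-out beyond the scatter. The expected outcome is therefore a step of a number 3.2 percentage points higher from compound 3 to compound 4 (within the scatter), nothing beyond the scatter. Compound 4 is estimated at 2%, with a range from -8% to 12%.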

Compound 4, a percentage reported as activity, at one concentration (the size of the read-out at that concentration, not a potency): 0%
Compound 4: middle estimate off by 2 percentage points, on the high side; the range from low to high includes it.
By their numbers in this assay, from the lowest: compounds 3, 4, 1 and 2 (each within the scatter of the next).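

In this assay a phenyl ring with fluorine as its only substituent reads like the others, with a number 1.2 percentage points higher from compound 3 to compound 4 (within the scatter) and a number 6.1 percentage points lower from compound 2 to compound 4 (within the scatter) and also a number 1 percentage points lower from compound 1 to compound 4 (within the scatter), so the aromatic groups tested so far on this ring nitrogen cannot be told apart. Within the data shown here, this now includes a direct swap of fluoro for chloro on an aromatic carbon, which the earlier compounds did not offer. Nothing available explains why these groups read alike. Still open, going by these compounds, is whether a phenyl ring bearing a carboxylic acid or an amine, or a cyclohexyl group in place of the aromatic ring, would read the same.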